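Chloro for hydrogen on the benzyl group of compound 2

The source may hold more compounds than are shown below. What is called first, only, known or untested is meant among the compounds shown, and "the series" means these compounds.

Measured so far:
compound 1, `CC1=C(C(=O)Nc2ccc([N+](=O)[O-])cc2)C(c2ccc(Br)cc2)N=C(SCc2ccccc2Cl)N1`, 9.7%
compound 2, `CC1=C(C(=O)Nc2ccc([N+](=O)[O-])cc2)C(c2cccc([N+](=O)[O-])c2)N=C(SCc2ccccc2)N1`, 27.2%

In a functional assay on the whole organism (artery, strain albino) with Rattus norvegicus as the target, with a stated time of 600 min, at a dose of 10 mg/kg by the oral route (a higher number here means more inhibition at the dose given (going by the name of the read-out), a lower number less inhibition), compound 2 stands highest of the two numbers; compound 1 is the nearest, a gap beyond the scatter. Compound 3, `CC1=C(C(=O)Nc2ccc([N+](=O)[O-])cc2)C(c2cccc([N+](=O)[O-])c2)N=C(SCc2ccccc2Cl)N1`, is not yet measured. It differs from compound 2 by chloro in place of hydrogen on an aromatic carbon. Compound 1 carries the same chloro group but also differs elsewhere, so its lower value cannot be tied to this change. The expected step of a number 6.2 percentage points lower from compound 2 to compound 3 (within the scatter) is small, downward, within the scatter. Compound 3 is expected to give 21% in this assay, with a range from 5% to 38%.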

Compound 3, a percentage reported as inhibition, in the whole organism at one dose (the size of the read-out at that dose, not a potency): 13.3%
For compound 3 the middle estimate is 7.7 percentage points above the measured one, and the stated range covers the measured number.
By their numbers in this assay, from the lowest: compounds 1 and 3 (each within the scatter of the next); then compound 2.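

In this assay, within the data shown here, chloro in place of hydrogen on the benzyl group, on an aromatic carbon ortho to a large group, gives the first single change that can be read (a number 13.9 percentage points lower from compound 2 to compound 3 (beyond the scatter)). With the 2-chlorobenzyl group held, 3-nitrophenyl in place of 4-bromophenyl on a saturated ring carbon gives a much smaller step (a number 3.6 percentage points higher from compound 1 to compound 3 (within the scatter)), so that change shows no effect here. Nothing measured explains the loss on adding chloro. From the compounds shown here alone, whether it is particular to chloro stays open: fluoro, methoxy or an amine on that carbon could behave differently.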